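Chloro in Place of Fluoro: Compound 3 to Compound 4

The source may report more compounds than this note shows. Statements on the series, on what has been measured and on what is new or still open speak of the compounds shown alone.

Compound 1 `CCN(C(=O)c1c(O)c2c(C)cccc2n(C)c1=O)c1ccccc1` — 65%
Compound 2 `CC(C)N(C(=O)c1c(O)c2c(Cl)cccc2n(C)c1=O)c1ccccc1` — 54%
Compound 3 `COc1cccc2c1c(O)c(C(=O)N(C)c1ccccc1F)c(=O)n2C` — 82%

All three measured compounds were tested in a functional assay on the whole organism for inhibition, with Mus musculus as the target, at a dose of 1 mg/kg by the oral route; a higher number here means more inhibition at the dose given (going by the name of the read-out), a lower number less inhibition. Compound 3 shows the highest number of the three. Its gap to compound 1, the nearest of the other two, lies beyond the usual scatter of repeated measurements, and its gap to compound 2, the furthest, lies beyond it as well. The three compounds differ from one another in more than one place at once, so none of these gaps can be tied to a single structural change.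

Compound 4 `COc1cccc2c1c(O)c(C(=O)N(C)c1ccccc1Cl)c(=O)n2C` has not yet been measured. It differs from compound 3 in exactly one place: chloro in place of fluoro on an aromatic carbon. One heavy atom leaves and one heavy atom enters, with no ring, no hydrogen-bond donor, no hydrogen-bond acceptor and no charge involved on either side.

For the measured compounds named here, no pair of measured compounds shows what such an exchange does in this assay. With so little changed, a step of a number 4 percentage points lower from compound 3 to compound 4 (within the scatter) is expected, which is to say no step beyond the scatter, in either direction. On that basis compound 4 is estimated to give about 78%, with a likely range from 60% to 92%.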

Compound 4, a percentage reported as inhibition, in the whole organism at one dose (the size of the read-out at that dose, not a potency): 50%
The estimate for compound 4 lay 28 percentage points above the measured number, outside the stated range (below it).
By their numbers in this assay, from the lowest: compounds 4 and 2 (each within the scatter of the next); then compound 1; then compound 3.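

In this assay, chloro in place of fluoro on an aromatic carbon, ortho to a large group, brings a number 32 percentage points lower from compound 3 to compound 4 (beyond the scatter) in a change that reads as 2-fluorophenyl to 2-chlorophenyl. This is the first pair shown that differs in one place only, and it reveals that this position is far from indifferent: one halogen exchanged for another, with no ring, hydrogen-bond donor, hydrogen-bond acceptor or charge involved, is enough to shift the number well beyond ordinary variation. Nothing at hand bears on why the step is so large.

On these data alone, what bromo, trifluoromethyl or a nitrile would give in this same place remains open, as does the shared core with a plain phenyl, which would show whether the gap comes more from the presence of fluoro or from the presence of chloro. Also open, as far as these compounds go, is whether the same exchange gives a step of this size in this assay when the rest of the molecule carries other groups, such as the ethyl of compound 1 or the isopropyl of compound 2.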